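Swapping the acid-bearing ring substituent on a prostaglandin D2 receptor ligand

This account rests on a few compounds, and the source may have more. Where it says the series, first, only, none or still open, it means among the compounds named here.

Measured so far:
compound 1, `CN1C[C@@H](COc2ccc(C(=O)N(C)c3cccc(CC(=O)O)c3)cc2)Oc2ccccc21`: 760 nM
compound 2, `Cc1cc(OC[C@@H]2CN(C)c3ccccc3O2)ccc1C(=O)Nc1cccc(CC(=O)O)c1C`: 59 nM

In an assay on CHO cells for displacement of a labelled ligand from prostaglandin D2 receptor (Mus musculus), read by scintillation counting, with a stated time of 60 min (a lower number here means a stronger inhibitor, a higher number a weaker inhibitor), compound 1 gives 760 nM, and compound 2 gives 59 nM, the lowest of the two numbers; the gap between them lies beyond the scatter. Compound 3, `Cc1cc(OC[C@@H]2CN(C)c3ccccc3O2)ccc1C(=O)Nc1ccc(F)c(CC(=O)O)c1`, has not yet been measured. It differs from compound 2 in one place: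

3-(carboxymethyl)-4-fluorophenyl in place of 3-(carboxymethyl)-2-methylphenyl on an amide-type nitrogen

Going by the values given here, no step between measured compounds shows what this exchange does, so the direction is uncertain. A small loss beyond the scatter is expected, with an estimated step of a 1.9-fold higher number from compound 2 to compound 3 (0.27 log units; within the scatter). Compound 3 is expected to give 110 nM, in the range 30 nM to 400 nM.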

Compound 3, inhibition constant: 15 nM
Compound 3: middle estimate off by 7.3-fold (0.87 log units), on the high side; measured number outside the range, below it.
By their numbers in this assay, from the lowest: compound 3; then compound 2; then compound 1.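

In this assay, putting 3-(carboxymethyl)-4-fluorophenyl in place of 3-(carboxymethyl)-2-methylphenyl on the amide-type nitrogen gives a 3.9-fold lower number from compound 2 to compound 3 (0.59 log units; beyond the scatter), so this position accepts a change of substituents on the acid-bearing ring. The methyl group of compound 2 is therefore not required for a low number here. Nothing available accounts for the gain.

Because the methyl group leaves and the fluorine enters in one exchange, the contribution of each remains unseparated. As far as these compounds go, it also remains open whether chlorine or a methoxy group in place of the fluorine would give a similar number.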